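The source may hold more compounds than are shown below. What is called first, only, known or untested is meant among the compounds shown, and "the series" means these compounds.

Working notes on the series in a functional assay on the whole organism (strain Kunming) with Mus musculus as the target, with a stated time of 0.5 h; a higher number here means that more compound is needed for the effect, a lower number that less compound is needed. Compound 1 `COc1cc(OC)c(OC)cc1/C=C/COC(=O)/C=C/c1ccc(Br)cc1` gives > 692 umol/kg, and this is a limit, not a number. Compound 2 `COc1cc(OC)c(OC)cc1/C=C/COC(=O)/C=C/c1ccccc1C(F)(F)F` gives > 710 umol/kg, which is also a limit. Compound 3 `COc1cc(OC)c(OC)cc1/C=C/COC(=O)/C=C/c1ccc(OC)c(OC)c1OC` gives > 674 umol/kg, again a limit. Compound 1 therefore has no readable position on the scale, and the other two values shown offer no number to compare it with.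

The next compound is compound 4 `COc1cccc(/C=C/C(=O)OC/C=C/c2cc(OC)c(OC)cc2OC)c1`, which differs from compound 1 as follows: 3-methoxyphenyl in place of 4-bromophenyl on a double-bonded chain carbon bound to a double-bonded chain carbon. The change is 3-methoxyphenyl in place of 4-bromophenyl on a double-bonded chain carbon bound to a double-bonded chain carbon. Among the measured compounds shown here, the only measured step at this place is a step that the two limits leave unreadable from compound 1 to compound 2. For the measured compounds named here, with that step as the sole evidence, neither a size nor a direction can be carried over, so no change beyond the scatter is expected in this assay. The expected step is a step that the limit leaves unreadable from compound 1 to compound 4. Compound 4 is estimated at 750 umol/kg, with an expected range from 400 umol/kg to 1100 umol/kg, and a report as a limit is the likeliest outcome.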

Compound 4, dose for half-maximal effect: 647 umol/kg
Estimate against measurement, compound 4: 1.2-fold (0.06 log units) above, and the stated range covers the measured number.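

In this assay compound 4 gives 647 umol/kg, the first actual number in the series shown, so the aryl group on a double-bonded chain carbon bound to a double-bonded chain carbon now has one readable point on the scale. With 3-methoxyphenyl as the entering group, the comparison gives an at least 1.0-fold lower number from compound 1 to compound 4 (0.02 log units; that floor lies within the scatter), and likewise an at least 1.0-fold lower number from compound 2 to compound 4 (0.04 log units; that floor lies within the scatter), so neither replacement is shown to move the result beyond the scatter. Both steps are floors and not full sizes, and the step between compound 1 and compound 2 cannot be read; the limit of compound 1 is the one these steps start from: the limit of > 692 umol/kg in this assay, at which 1 of the 4 values shown sits.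

From the compounds shown here alone, it remains open how far the true values of compound 1, compound 2 and compound 3 lie from that of compound 4, and so whether the 3-methoxyphenyl group changes anything at all at this place. Going by these compounds, it is also open whether a phenyl ring carrying an amine or a carboxylic acid at this place, or an amide in place of the ester link, would give a number clearly apart from compound 4 at 647 umol/kg.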